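Working notes: from compound 3 to compound 4

The source may report more compounds than this note shows. Statements on the series, on what has been measured and on what is new or still open speak of the compounds shown alone.

compound 1 `CC(=O)c1ccc2[nH]c(-c3ccccc3)nc2c1` gives > 100000 nM (a limit)
compound 2 `CC(=O)c1ccc2[nH]c(-c3ccc(Cl)cc3)nc2c1` gives > 100000 nM (a limit)
compound 3 `COc1ccc(-c2nc3cc(C(C)=O)ccc3[nH]2)c(OC)c1` gives 50000 nM (a number)

Within the data shown here, in an ADME assay on BHK-21 cells (Mesocricetus auratus) for cytotoxicity, read by MTT assay (on this read-out lower numbers stand for higher toxicity in this test and higher numbers for lower toxicity in this test), compound 3 gives 50000 nM as the only actual number so far. For compound 1 the reading > 100000 nM is a limit. For compound 2 the reading > 100000 nM is also a limit. The other two values thus rest on the limit of > 100000 nM in this assay, at which 2 of the 3 values shown sit, and not on numbers.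

Compound 4 `COc1ccc(-c2nc3cc(C(C)=O)ccc3[nH]2)c(OC)c1OC` is the next to be read. Its change from compound 3 is methoxy in place of hydrogen on an aromatic carbon in counted terms, methoxy in place of hydrogen on an aromatic carbon. Among the measured compounds shown here, the one measured step that the two limits leave unreadable from compound 1 to compound 2 brings in chloro rather than methoxy and gives no size to carry over. The expectation therefore rests on compound 3 at 50000 nM alone, and no step beyond the scatter is expected in this assay in either direction. The estimated change is no change at the digits printed from compound 3 to compound 4 (within the scatter) and no more. Compound 4 is estimated at 50000 nM with an expected range from 20000 nM to 100000 nM for this reading.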

Compound 4, half-maximal cytotoxic concentration: > 100000 nM
Compound 4 ended at the assay's limit; the forecaster's own chance of this, stated with the estimate: 20%; middle value at least 2.0-fold (0.30 log units) from the limit.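

In this assay, methoxy in place of hydrogen on an aromatic carbon, ortho to two methoxy groups, gives an at least 2.0-fold higher number from compound 3 to compound 4 (0.30 log units; that floor lies within the scatter). Compound 4 reads > 100000 nM, which is a limit and not a number. At this position methoxy therefore brings no lower number on this read-out, and the step has only a floor and no measured size, so compound 3 remains the sole compound with an actual number: the limit of > 100000 nM in this assay, at which 3 of the 4 values shown sit.

Going by these compounds, the step between the two compounds that both sit at the limit cannot be read, and the true size of the step at this position stays unknown. Also open, on these data alone, is how this position would read with an amine, a carboxylic acid or a longer alkoxy chain in place of methoxy.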